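The compounds below may be only part of what the source reports. "The series", "measured", "known", "first", "only" and "open" are said of these compounds alone.

Measured so far in a functional assay on MDA-MB-468 cells (Homo sapiens) for inhibition, read by sulforhodamine B assay, with a stated time of 48 h; on this read-out higher numbers stand for weaker inhibition of growth and lower numbers for stronger inhibition of growth:
- compound 1 `Cc1ccc(NC(=O)/C=C/c2ccccc2)c(C(N)=O)c1`: 3120 nM
- compound 2 `NC(=O)c1cc(I)ccc1NC(=O)/C=C/c1ccccc1`: "not determined" (no result reported)

Only compound 1 has a number in this assay, and it gives 3120 nM. Compound 2 stands without a single number, so it cannot be placed against compound 1 and offers no measured baseline for what follows.

Compound 3 `NC(=O)c1cc(I)ccc1NC(=O)/C=C/c1ccccc1Cl` comes from compound 2 by one change: chloro in place of hydrogen on an aromatic carbon. In words, a chloro replaces hydrogen on an aromatic carbon, taking phenyl to 2-chlorophenyl. Among the measured compounds shown here, no measured pair shows what such a change does, so any expectation is a loose one. A modest step is expected in this assay, perhaps slightly towards stronger inhibition of growth, though one not clearly beyond the usual scatter. For the measured compounds named here, the only numerical anchor is compound 1 at 3120 nM, so the expected value sits in the same low micromolar region, with a wide range. For compound 3 the estimated value is 2000 nM, with an expected range from 500 nM to 8000 nM.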

Compound 3, concentration for 50% growth inhibition: 377 nM
Beside the measured number, compound 3's estimate is 5.3-fold (0.72 log units) above it; the whole stated range lies above it.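

In this assay, among the compounds shown here, compound 3 gives 377 nM, but compound 2 has no single number, so no step from compound 2 to compound 3 can be read. The compounds shown leave open what the change from phenyl to 2-chlorophenyl does on its own to inhibition of growth. No outside evidence bears on this result.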